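This account rests on a few compounds, and the source may have more. Where it says the series, first, only, none or still open, it means among the compounds named here.

In an ADME assay on HEK293 cells (Homo sapiens) for cytotoxicity, read by MTT assay (a higher number here means a weaker inhibitor, a lower number a stronger inhibitor), compound 2 `O=c1n(Cc2cn(Cc3cc4cc(Cl)ccc4nc3Cl)nn2)cnn1-c1ccccc1` gives 459 ug/mL. Compound 1 `COc1ccc(-n2ncn(Cc3cn(Cc4cc5cc(Cl)ccc5nc4Cl)nn3)c2=O)cc1` differs from compound 2 by methoxy in place of hydrogen on an aromatic carbon, and in this assay compound 1 gives 1060 ug/mL; the step between them, a 2.3-fold higher number from compound 2 to compound 1 (0.36 log units; beyond the scatter), is a modest one. Compound 3 `O=c1n(Cc2cn(Cc3cc4ccccc4nc3Cl)nn2)cnn1-c1ccccc1` differs from compound 2 by hydrogen in place of chloro on an aromatic carbon, and in this assay compound 3 gives 655 ug/mL, a step of a 1.4-fold higher number from compound 2 to compound 3 (0.15 log units; within the scatter).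

Compound 4 `COc1ccc2cc(Cn3cc(Cn4cnn(-c5ccccc5)c4=O)nn3)c(Cl)nc2c1` has not yet been measured. It differs from compound 3 by methoxy in place of hydrogen on an aromatic carbon. Going by the values given here, this is the same kind of change as the one from compound 2 to compound 1, not the same change: here the methoxy enters on a six-membered aromatic ring of carbon only that is part of a fused or bridged system of two rings, meta to a fused ring and para to a fused ring, whereas in compound 1 it enters on a six-membered aromatic ring of carbon only, para to a large group.

The step from compound 3 to compound 4 is expected to be a 1.5-fold higher number from compound 3 to compound 4 (0.16 log units; within the scatter), a guess that rests on the earlier step of a 2.3-fold higher number from compound 2 to compound 1 (0.36 log units; beyond the scatter) while allowing for the different place. Compound 4 is therefore expected to give about 950 ug/mL in this assay, most likely between 450 ug/mL and 2000 ug/mL.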

Compound 4, half-maximal inhibitory concentration: 1010 ug/mL
Compound 4: middle estimate off by 1.1-fold (0.03 log units), on the low side; the range from low to high includes it.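

In this assay putting methoxy in place of hydrogen gives a 1.5-fold higher number from compound 3 to compound 4 (0.19 log units; within the scatter) and so, on this core, cannot be told apart from the ordinary spread of repeated measurements. Set beside the earlier step on the other core, the new step shows no real difference, so as far as these two pairs can tell, the change carries over from one core to the other: the same change on two cores in this assay, a 2.3-fold higher number (0.36 log units; beyond the scatter) from compound 2 to compound 1 and a 1.5-fold higher number (0.19 log units; within the scatter) from compound 3 to compound 4, 1.5-fold (0.18 log units) apart, within the scatter of two such steps. Going by these compounds alone, this rests on only two pairs with the methoxy in two different places, so it does not show that the step would keep its size on other cores or that a rule holds across the series.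

The compounds shown leave open whether an amine, a hydroxyl or a carboxylic acid in place of the methoxy would give a step beyond the scatter. They also leave open what a longer chain such as ethoxy would do at either place.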